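Swapping the Aryl Group on the Piperazine Nitrogen

The source may report more compounds than this note shows. Statements on the series, on what has been measured and on what is new or still open speak of the compounds shown alone.

Compound 1, `CCc1nc(-c2cccc(F)c2)c(C(=O)N2CCN(c3cccc(OC)c3)CC2)o1`: 201 nM
Compound 2, `Cc1nc(-c2ccccc2)c(C(=O)N2CCN(c3ccc(C(F)(F)F)cc3)CC2)o1`: > 1000 nM

Of the compounds shown here, two that share a core have been measured in a functional assay on HL-60 cells (Homo sapiens) for inhibition, read by MTT assay, with a stated time of 72 h; on this read-out lower numbers stand for stronger inhibition and higher numbers for weaker inhibition. Compound 1 gives 201 nM. For compound 2 only a limit is known, > 1000 nM, so compound 2 sits at the limit of > 1000 nM in this assay, at which 1 of the 2 values shown sits, and its true value beyond that is not known. Compound 3, `Cc1nc(-c2ccccc2)c(C(=O)N2CCN(c3cccc(F)c3)CC2)o1`, has not been measured. It differs from compound 2 in one place: 3-fluorophenyl in place of 4-(trifluoromethyl)phenyl on an amine nitrogen in a ring. Among the compounds with values here, the group that enters is the one compound 1 carries on the same ring nitrogen, yet compound 3 also differs from compound 1 in other places, so no measured step covers this change directly. Compound 2 is known only as a limit, so the step to compound 3 cannot be sized with confidence. The step of an at least 1.6-fold lower number from compound 2 to compound 3 (0.22 log units; that floor lies within the scatter) is expected to go toward stronger inhibition, though it could stay within the scatter. Compound 3 is therefore estimated at 600 nM, with a range from 200 nM to 3000 nM.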

Compound 3, half-maximal inhibitory concentration: 45 nM
For compound 3 the middle estimate is 13-fold (1.12 log units) above the measured one, and the stated range ends above it.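

With the rest of the molecule unchanged, putting 3-fluorophenyl in place of 4-(trifluoromethyl)phenyl on the amine nitrogen in a ring gives an at least 22-fold lower number from compound 2 to compound 3 (1.34 log units; beyond the scatter) in this assay. Compounds 1 and 2 differ in several places and could not isolate this group, whereas this pair shows that the aryl group on this ring nitrogen can, on its own, shift the read-out by more than the usual scatter. Compound 2 is known only as a limit and not as a number, so this step is a minimum and its true size remains unknown: the limit of > 1000 nM in this assay, at which 1 of the 3 values shown sits.

The change alters both the group on the phenyl ring and the place it occupies, so this pair cannot separate those two effects. On these data alone, how plain phenyl or 4-fluorophenyl on the same ring nitrogen would behave in this assay remains open.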